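This account rests on a few compounds, and the source may have more. Where it says the series, first, only, none or still open, it means among the compounds named here.

Measured so far in an assay on HeLa cells for inhibition of sphingosine-1-phosphate transporter SPNS2 (Mus musculus), read by LC-MS, tested at 2 uM; a lower number here means less inhibition, a higher number more inhibition at the concentration tested (going by the name of the read-out):
compound 1 `CCCCCCCCCCc1ccc(-c2noc(CC(O)CN)n2)cc1` gives 59%
compound 2 `CCCCCCCCCCc1ccc(-c2noc([C@@H](N)CCN)n2)cc1` gives 14%
compound 3 `CCCCCCCCCCc1ccc(-c2noc([C@H](N)CCCCN)n2)cc1` gives 50%

Compound 3 stands second highest of the three. Its nearest neighbour is compound 1, a number 9 percentage points lower from compound 1 to compound 3 (within the scatter); its furthest is compound 2, a number 36 percentage points higher from compound 2 to compound 3 (beyond the scatter). Compound 4 `CCCCCCCCCCc1ccc(-c2noc(CC(O)CN3CCCC3)n2)cc1` is not yet measured and differs from compound 3 by 2-hydroxy-3-(pyrrolidin-1-yl)propyl in place of 1,5-diaminopentyl on an aromatic carbon. Among the measured compounds shown here, in build compound 4 is closer to compound 1 than to compound 3, and the only measured step that bears on it is a number 9 percentage points lower from compound 1 to compound 3 (within the scatter), which lay within the scatter. For the measured compounds named here, no measured step covers the pyrrolidin-1-yl on the side chain. The expectation for compound 4 is therefore no step beyond the scatter, no change at the digits printed from compound 3 to compound 4 (within the scatter), with wide uncertainty. Compound 4 is estimated at 50%, ranging from 20% to 80%.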

Compound 4, a percentage reported as inhibition, at one concentration (the size of the read-out at that concentration, not a potency): 21%
For compound 4 the middle estimate is 29 percentage points above the measured one; low and high end bracket the measured number.
By their numbers in this assay, from the lowest: compounds 2 and 4 (each within the scatter of the next); then compounds 3 and 1 (each within the scatter of the next).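

In this assay, pyrrolidin-1-yl in place of amino on the hydroxypropyl chain gives a number 38 percentage points lower from compound 1 to compound 4 (beyond the scatter), so at this position the read-out depends on which amine the chain carries. Against the diamine chains the result splits, with a number 29 percentage points lower from compound 3 to compound 4 (beyond the scatter) but a number 7 percentage points higher from compound 2 to compound 4 (within the scatter), which places 2-hydroxy-3-(pyrrolidin-1-yl)propyl level with 1,3-diaminopropyl and not with 1,5-diaminopentyl. No supporting data bear on these steps.

Still open, as far as these compounds go, is how a dimethylamino or piperidin-1-yl group would read on the same hydroxypropyl chain. Also open, from the compounds shown here alone, is what a carboxylic acid in place of the amine would give.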